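Bombesin receptor subtype-3 series: compound 2 to compound 4

This account rests on a few compounds, and the source may have more. Where it says the series, first, only, none or still open, it means among the compounds named here.

Compound 2 `O=C(O)c1ccccc1-c1ccc(CCc2ncc(CC3CCC3)[nH]2)cc1` gives 7.1 nM in an in vitro functional assay on cells for agonist activity at Bombesin receptor subtype-3 (Mus musculus), read by luminescence and calcium flux (a higher number here means that more compound is needed for the effect, a lower number that less compound is needed), and holds the lowest number of the two measured there. Compound 3 `O=C(O)c1ccccc1-c1ccc(CCc2ncc(C3CCCCC3)[nH]2)cc1` gives 14.7 nM; the step of a 2.1-fold higher number from compound 2 to compound 3 (0.32 log units; beyond the scatter) is the only measured one. Compound 1 `CCCCc1cnc(Cc2ccc(-c3ccccc3C(=O)O)cc2)[nH]1` reaches only the assay limit (the limit of > 10000 nM in this assay, at which 1 of the 3 values shown sits), so compound 1 gives > 10000 nM as a limit, not a number. Compound 4 `Cc1cccc(Cc2cnc(CCc3ccc(-c4ccccc4C(=O)O)cc3)[nH]2)c1` is not yet measured; it differs from compound 2 by 3-methylphenyl in place of cyclobutyl on a saturated chain carbon bound to an aromatic carbon. Within the data shown here, the one relevant step is the modest rise from compound 2 to compound 3, so a comparable small shift is expected here. Compound 4 is estimated at 10 nM, range 3 nM to 40 nM, giving an expected step of a 1.4-fold higher number from compound 2 to compound 4 (0.15 log units; within the scatter).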

Compound 4, half-maximal effective concentration: 75 nM
Compound 4: the middle estimate sits 7.5-fold (0.88 log units) below what was measured; the whole stated range lies below it.
By their numbers in this assay, from the lowest: compound 2; then compound 3; then compound 4. At a limit, above all of these: compound 1.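

The position accepts 3-methylbenzyl, but at a clear cost against both saturated groups (an 11-fold higher number from compound 2 to compound 4 (1.02 log units; beyond the scatter); a 5.1-fold higher number from compound 3 to compound 4 (0.71 log units; beyond the scatter)). The move to an aromatic ring therefore changes the number much more than the change from cyclobutylmethyl to cyclohexyl did, though this rests on compound 4 alone. Nothing in the supporting data bears on this result.

Going by these compounds, it remains open whether the loss follows the aromatic ring or its methyl group. Plain benzyl, or a benzyl carrying a methoxy group or an amine, would help separate these.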